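Swapping a Branched Alkenyl Chain for a Cyclohexyl Ring

This account rests on a few compounds, and the source may have more. Where it says the series, first, only, none or still open, it means among the compounds named here.

Compound 1: `CC(C)CCN(C1=NCCN1)c1c(Br)cccc1Br`, 0.16
Compound 2: `CC(C)=CCN(C1=NCCN1)c1c(Br)cccc1Br`, -0.14

In a physicochemical assay for lipophilicity (a lower number here means a more polar compound, a higher number a more lipophilic compound), compound 2 gives -0.14, the lowest of the two numbers, while compound 1 gives 0.16; a number 0.30 log units lower from compound 1 to compound 2 (within the scatter). Compound 3, `Brc1cccc(Br)c1N(C1=NCCN1)C1CCCCC1`, carries cyclohexyl in place of 3-methylbut-2-en-1-yl on a nitrogen on an aromatic ring. Among the compounds with values here, no measured step exchanges a chain for a ring, so the single measured step offers only a loose guide, showing that a change at this nitrogen moved the number little. For cyclohexyl in place of 3-methylbut-2-en-1-yl, a rise is nonetheless expected, estimated as a number 0.54 log units higher from compound 2 to compound 3 (beyond the scatter). Compound 3 is therefore expected at 0.4, between 0 and 0.8.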

Compound 3, distribution coefficient: 0.14
Beside the measured number, compound 3's estimate is 0.26 log units above it, within the range that was stated.
By their numbers in this assay, from the lowest: compounds 2, 3 and 1 (each within the scatter of the next).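

In this assay, within the data shown here, cyclohexyl on this nitrogen on an aromatic ring gives the first exchange of an open chain for a ring, both with 3-methylbut-2-en-1-yl leaving (a number 0.28 log units higher from compound 2 to compound 3 (within the scatter)) and with isopentyl leaving (a number 0.02 log units lower from compound 1 to compound 3 (within the scatter)). Both steps lie within the scatter, so in these three compounds a ring and an open chain at this position cannot be told apart by this read-out.

On these data alone, what an amine or a carboxylic acid at this nitrogen would give remains open. No further measurement here offers an explanation for these numbers.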